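Chloro in place of trifluoromethyl on a diaryl urea

The compounds below may be only part of what the source reports. "The series", "measured", "known", "first", "only" and "open" are said of these compounds alone.

The series rests on a shared core carrying a diaryl urea. Compound 1 `COc1cc2cc(Oc3ccc(NC(=O)Nc4cccc(C(F)(F)F)c4)cc3)c(C)nc2cc1OC` is measured in a functional assay on SK-MEL-5 cells (Homo sapiens) for inhibition, read by sulforhodamine B assay, with a stated time of 48 h; a higher number here means that more compound is tolerated, a lower number that less compound is tolerated; in that assay compound 1 gives 8470 nM. Compound 2 `COc1cc2cc(Oc3ccc(NC(=O)Nc4ccc(Cl)c(C(F)(F)F)c4)cc3)c(C)nc2cc1OC` adds chloro in place of hydrogen on an aromatic carbon, and in this assay compound 2 gives 8010 nM. The step of a 1.1-fold lower number from compound 1 to compound 2 (0.02 log units; within the scatter) is within the scatter, so compound 2 cannot be set apart from compound 1 on the two numbers available: both tolerate the compound to a similar degree.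

Compound 3 `COc1cc2cc(Oc3ccc(NC(=O)Nc4ccc(Cl)c(Cl)c4)cc3)c(C)nc2cc1OC` differs from compound 2 by chloro in place of trifluoromethyl on an aromatic carbon. Among the measured compounds shown here, no measured step replaces trifluoromethyl with chloro, so the only guidance is the step from compound 1 to compound 2, where a change on the same ring left this assay unmoved. On that basis the step from compound 2 to compound 3 is expected to be a 1.1-fold higher number from compound 2 to compound 3 (0.03 log units; within the scatter), with no movement beyond the scatter. Compound 3 is therefore estimated at 8500 nM in this assay, with a range from 4000 nM to 17000 nM.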

Compound 3, concentration lethal to 50% of the cells: 30800 nM
Estimate against measurement, compound 3: 3.6-fold (0.56 log units) below; the measured number lies above the stated range.
By their numbers in this assay, from the lowest: compounds 2 and 1 (each within the scatter of the next); then compound 3.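

Unlike the change of hydrogen to chloro on the same ring, which gave a 1.1-fold lower number from compound 1 to compound 2 (0.02 log units; within the scatter) in this assay, this position responds to which group it carries: chloro in place of trifluoromethyl, ortho to a chloro group, gives a 3.8-fold higher number from compound 2 to compound 3 (0.58 log units; beyond the scatter) and so moves the number beyond the scatter. The comparison with the compound lacking the second chloro agrees, as 3,4-dichlorophenyl in place of 3-(trifluoromethyl)phenyl on the urea nitrogen gives a 3.6-fold higher number from compound 1 to compound 3 (0.56 log units; beyond the scatter) and sets compound 3 apart from both compounds that carry trifluoromethyl. Among these three compounds, then, the one without trifluoromethyl is the one that stands apart, while the presence or absence of the chloro ortho to that position makes no difference that can be read when trifluoromethyl is present, and nothing shown here gives a reason for the shift.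

On these data alone, whether the same change would give a similar step on a ring without the second chloro remains open. As far as these compounds go, it is also open where other groups at this position, such as bromo, methyl or nitrile, would fall relative to trifluoromethyl and chloro.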